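A few compounds are considered here, and "the series" means these few. Any claim that something is new, unique, unknown or untested is made for them only; others in the source may bear on it.

Measured compounds in a functional assay on the whole organism (strain Kunming) for inhibition, with Mus musculus as the target, in the writhing test, at a dose of 40 mg/kg by the oral route; on this read-out lower numbers stand for less inhibition and higher numbers for more inhibition at the one dose given (going by the name of the read-out):
- compound 1, `CC(=O)Oc1ccc(-c2ccc(F)cc2F)cc1C(=O)O`, gives 0%
- compound 2, `CC(=O)Oc1ccc(-c2ccc(F)cc2F)cc1C(=O)NCc1ccccc1`, gives 16.6%
- compound 3, `CC(=O)Oc1ccc(-c2ccc(F)cc2F)cc1C(=O)Nc1cccc(C)c1`, gives 19%

Compound 1 stands lowest of the three numbers, showing no inhibition at the dose used. Both other compounds carry an amide in place of its carboxylic acid, and both sit beyond the usual scatter above it: a number 16.6 percentage points higher from compound 1 to compound 2 (beyond the scatter) and a number 19 percentage points higher from compound 1 to compound 3 (beyond the scatter). The two amides themselves cannot be told apart, since a number 2.4 percentage points higher from compound 2 to compound 3 (within the scatter).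

Compound 4, `CC(=O)Oc1ccc(-c2ccc(F)cc2F)cc1C(=O)Nc1cc(C)ccc1C`, has not been measured. It differs from compound 1 at one place: (2,5-dimethylphenyl)amino in place of hydroxy on a carbonyl carbon. This is the same kind of change as the two measured steps, an amide in place of the acid on the carbonyl carbon, only with a differently substituted aromatic ring on the amide nitrogen.

The two comparable steps were both modest rises of similar size, and switching between a benzyl and a 3-methylphenyl group on the nitrogen made no difference beyond the scatter. A modest rise is therefore expected, a number 19 percentage points higher from compound 1 to compound 4 (beyond the scatter). Compound 4 is estimated to give 19% in this assay, with a range from 5% to 33%.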

Compound 4, a percentage reported as inhibition, in the whole organism at one dose (the size of the read-out at that dose, not a potency): 13.2%
The estimate for compound 4 lay 5.8 percentage points above the measured number, and the stated range covers the measured number.
By their numbers in this assay, from the lowest: compound 1; then compounds 4, 2 and 3 (each within the scatter of the next).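

In this assay, a third amide again stands clear of the carboxylic acid, with a number 13.2 percentage points higher from compound 1 to compound 4 (beyond the scatter), so the rise on placing an amide on this carbonyl carbon now holds for benzylamino, (3-methylphenyl)amino and (2,5-dimethylphenyl)amino alike. The finer changes on the amide nitrogen do not separate the compounds: methyl in place of hydrogen on an aromatic carbon gives a number 5.8 percentage points lower from compound 3 to compound 4 (within the scatter), and 2,5-dimethylphenyl in place of benzyl gives a number 3.4 percentage points lower from compound 2 to compound 4 (within the scatter), so these three amides cannot be told apart in this read-out. Nothing available explains why the amides differ from the acid or why the three amides fall so close together.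

Every amide shown carries an aromatic ring on its nitrogen, which leaves open how the read-out would respond to a short alkyl chain such as ethyl, to a morpholine ring in that place, or to an aromatic ring bearing methoxy or chlorine. Going by these compounds, every number also comes from a single dose, so how these amides would compare at other doses remains open too.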